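Urea series: chloro position on the terminal phenyl ring

The compounds below may be only part of what the source reports. "The series", "measured", "known", "first", "only" and "open" are said of these compounds alone.

Values in a functional assay on MKN-45 cells (Homo sapiens) for cytotoxicity, read by MTT assay, with a stated time of 72 h; on this read-out higher numbers stand for weaker inhibition and lower numbers for stronger inhibition:
Compound 1, `CCN(CC)CCCNc1nc(-c2ccc(NC(=O)Nc3ccc(Cl)cc3)cc2)nc2c(Cl)c(Cl)sc12`: 720 nM
Compound 2, `CCN(CC)CCCNc1nc(-c2ccc(NC(=O)Nc3ccccc3Cl)cc2)nc2c(Cl)c(Cl)sc12`: 1450 nM
Compound 3, `CCN(CC)CCCNc1nc(-c2ccc(NC(=O)Nc3ccc(Cl)cc3)cc2)nc2ccsc12`: 180 nM

Compound 3 is the strongest of the three; its steps to compound 1 and compound 2 both lie beyond the scatter. The difference between the core of compound 3 and the core of compound 1 is not broken down here.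

Compound 1 and compound 2 differ by 2-chlorophenyl in place of 4-chlorophenyl on an amide-type nitrogen, and that change gave a 2.0-fold higher number from compound 1 to compound 2 (0.30 log units; within the scatter).

Compound 4, `CCN(CC)CCCNc1nc(-c2ccc(NC(=O)Nc3ccccc3Cl)cc2)nc2ccsc12`, is not yet measured. It differs from compound 3 by 2-chlorophenyl in place of 4-chlorophenyl on an amide-type nitrogen, the same change at the same place, now on the core of compound 3. Compound 4 is expected to show a 2.0-fold higher number from compound 3 to compound 4 (0.30 log units; within the scatter), because the change from compound 1 to compound 2 gave a 2.0-fold higher number from compound 1 to compound 2 (0.30 log units; within the scatter). For compound 4 the estimate is 360 nM, with a likely range from 180 nM to 800 nM.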

Compound 4, half-maximal inhibitory concentration: 390 nM
The estimate for compound 4 lay 1.1-fold (0.03 log units) below the measured number; the range from low to high includes it.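

In this assay, 2-chlorophenyl in place of 4-chlorophenyl on the amide-type nitrogen of the core of compound 3 gave a 2.2-fold higher number from compound 3 to compound 4 (0.34 log units; beyond the scatter). The change carried over between the two cores with much the same size: the same change on two cores in this assay, a 2.0-fold higher number (0.30 log units; within the scatter) from compound 1 to compound 2 and a 2.2-fold higher number (0.34 log units; beyond the scatter) from compound 3 to compound 4, 1.1-fold (0.03 log units) apart, within the scatter of two such steps

Among the compounds shown here, this agreement rests on only two cores and one swap of chlorophenyl groups, so it does not show that the change would transfer to any other core, nor does it explain the shift.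

On these data alone, the terminal ring carries only chlorine in these compounds, so the effect of bromine, methoxy or trifluoromethyl there remains open. The diethylamino propyl chain is also constant, leaving open whether a morpholine or a longer chain would alter the step.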